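The source may hold more compounds than are shown below. What is called first, only, known or untested is meant among the compounds shown, and "the series" means these compounds.

Compound 1 `O=C(NN1CCOCC1)c1c(O)c2cccnc2n(-c2ccccc2)c1=O` and compound 2 `Nc1ccc(NC(=O)c2c(O)c3cccnc3n(-c3ccccc3)c2=O)cc1` share one core and differ at an amide-type nitrogen. In a functional assay on the whole organism for inhibition, with Rattus norvegicus as the target, read by paw edema, at a dose of 100 mg/kg by the oral route (on this read-out lower numbers stand for less inhibition and higher numbers for more inhibition at the one dose given (going by the name of the read-out)), compound 1 gives -8.5%, while compound 2 gives -5.5%. Among the compounds with values here, the only measured step, a number 3 percentage points higher from compound 1 to compound 2 (within the scatter), lies within the scatter, so compound 2 stands alongside compound 1 with no separation beyond the scatter. Compound 3 `O=C(Nc1cccc(Cl)c1)c1c(O)c2cccnc2n(-c2ccccc2)c1=O` differs from compound 2 in that (3-chlorophenyl in place of 4-aminophenyl on an amide-type nitrogen). Within the data shown here, because the one step at this nitrogen, a number 3 percentage points higher from compound 1 to compound 2 (within the scatter), was within the scatter, no change beyond the scatter is expected in this assay. For compound 3 the expected step is a number 0.5 percentage points higher from compound 2 to compound 3 (within the scatter). Compound 3 is estimated at -5%, ranging from -20% to 12%.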

Compound 3, a percentage reported as inhibition, in the whole organism at one dose (the size of the read-out at that dose, not a potency): 7.6%
For compound 3 the middle estimate is 12.6 percentage points below the measured one, and the stated range covers the measured number.
By their numbers in this assay, from the lowest: compounds 1 and 2 (each within the scatter of the next); then compound 3.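

In this assay the amide-type nitrogen turns out to matter: 3-chlorophenyl in place of 4-aminophenyl gives a number 13.1 percentage points higher from compound 2 to compound 3 (beyond the scatter) and 3-chlorophenyl in place of morpholin-4-yl gives a number 16.1 percentage points higher from compound 1 to compound 3 (beyond the scatter). The pair of compound 1 and compound 2 did not show that this position can shift the read-out, and only compound 3 now gives a number above zero. Nothing given here explains the step. As far as these compounds go, whether a plain phenyl, a 4-chlorophenyl or a 3-methoxyphenyl on this nitrogen would behave like 3-chlorophenyl stays open, and so does whether the difference holds at other doses.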